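Changing the Group on the Sulfonyl Sulfur

A few compounds are considered here, and "the series" means these few. Any claim that something is new, unique, unknown or untested is made for them only; others in the source may bear on it.

Compound 1, `Cn1c(=O)c(S(=O)(=O)c2ccc(F)cc2F)cc2cnc(Nc3ccc4cc[nH]c4c3)nc21`: 5000 nM
Compound 2, `Cn1c(=O)c(S(=O)(=O)Cc2ccc(F)cc2F)cc2cnc(Nc3ccc4[nH]ccc4c3)nc21`: 1000 nM
Compound 3, `Cn1ccc2cc(Nc3ncc4cc(S(=O)(=O)c5ccc(F)cc5F)c(=O)n(C)c4n3)ccc21`: 750 nM

Of the compounds shown here, three with a shared core have been tested in a functional assay on DU-145 cells (Homo sapiens) for inhibition, read by trypan blue exclusion, with a stated time of 72 h; on this read-out higher numbers stand for weaker inhibition and lower numbers for stronger inhibition. Compound 2 gives 1000 nM, the second highest of the three numbers. Its nearest neighbour is compound 3, whose number is lower but within the scatter, so the two cannot be ordered. Its furthest neighbour is compound 1, whose number is higher and beyond the scatter. Going by the values given here, the only step between compounds that differ in one place is a 6.7-fold lower number from compound 1 to compound 3 (0.82 log units; beyond the scatter), and it concerns the group on the ring nitrogen, not the sulfone.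

Compound 4, `Cn1c(=O)c(S(=O)(=O)c2ccc(O)cc2)cc2cnc(Nc3ccc4[nH]ccc4c3)nc21`, differs from compound 2 by 4-hydroxyphenyl in place of 2,4-difluorobenzyl on a sulfonyl sulfur. Among the compounds with values here, no measured step touches the group on the sulfonyl sulfur. Compound 1 and compound 2 do differ there, but they also differ in the indole, so their values give no clean reading of this change. With nothing to guide the direction, the expected step of a 1.5-fold higher number from compound 2 to compound 4 (0.18 log units; within the scatter) is none beyond the scatter, with wide uncertainty. Compound 4 is therefore estimated at 1500 nM, within 300 nM to 8000 nM.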

Compound 4, half-maximal inhibitory concentration: 250 nM
Compound 4: middle estimate off by 6.0-fold (0.78 log units), on the high side; measured number below the stated range.
By their numbers in this assay, from the lowest: compound 4; then compounds 3 and 2 (each within the scatter of the next); then compound 1.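

Going by these compounds alone, compound 4 gives the first clean reading of the group on the sulfonyl sulfur. In this assay, putting 4-hydroxyphenyl in place of 2,4-difluorobenzyl brings a 4.0-fold lower number from compound 2 to compound 4 (0.60 log units; beyond the scatter), which shows that the number responds to this group while the rest of the molecule stays fixed. The whole group changes in a single step, so the contributions of its parts cannot be separated, and no measurement at hand explains the result.

The compounds shown leave open which part of the change matters: a plain phenyl, a hydroxybenzyl or a methoxyphenyl group on the sulfonyl sulfur would help to separate them. Also open, as far as these compounds go, is whether the same step would hold with a 1-methyl-1H-indol-5-yl group on the shared core.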